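The source may report more compounds than this note shows. Statements on the series, on what has been measured and on what is new or still open speak of the compounds shown alone.

Three related compounds with a shared core have been measured. Compound 1, `Cc1cc(Cl)c(S(C)(=O)=O)cc1C(=O)N=C(N)N`, gives 25 nM in a functional assay for inhibition of sodium/hydrogen exchanger (Oryctolagus cuniculus); on this read-out lower numbers stand for stronger inhibition and higher numbers for weaker inhibition. Compound 2, `Cc1cc(-c2ccc(F)cc2)c(S(C)(=O)=O)cc1C(=O)N=C(N)N`, gives 36 nM, and compound 3, `Cc1cc(-c2ccccc2)c(S(C)(=O)=O)cc1C(=O)N=C(N)N`, gives 19 nM. Compound 3 sits at the low end of these three numbers, yet both of its neighbours lie within the scatter: a 1.3-fold lower number from compound 1 to compound 3 (0.12 log units; within the scatter) and a 1.9-fold lower number from compound 2 to compound 3 (0.28 log units; within the scatter).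

Compound 4, `Cc1cc(Sc2ccccc2Cl)c(S(C)(=O)=O)cc1C(=O)N=C(N)N`, differs from compound 3 in one place: (2-chlorophenyl)sulfanyl in place of phenyl on an aromatic carbon. Among the measured compounds shown here, the measured steps that come closest are the exchange of chloro for phenyl, a 1.3-fold lower number from compound 1 to compound 3 (0.12 log units; within the scatter), and the removal of fluoro from the phenyl, a 1.9-fold lower number from compound 2 to compound 3 (0.28 log units; within the scatter); both stayed within the scatter, and no measured step tells what a sulfanyl link or a chloro on that ring does. The expected step in this assay is therefore small, a 1.3-fold higher number from compound 3 to compound 4 (0.12 log units; within the scatter), without a clear direction beyond the scatter. The estimate for compound 4 is 25 nM, with a range from 8 nM to 80 nM.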

Compound 4, half-maximal inhibitory concentration: 14 nM
Compound 4: middle estimate off by 1.8-fold (0.25 log units), on the high side; the measured number falls inside the stated range.
By their numbers in this assay, from the lowest: compounds 4, 3, 1 and 2 (each within the scatter of the next, the first and the last beyond it).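

This position takes a ring joined through sulfur about as well as a ring joined directly: in this assay there is a 1.4-fold lower number from compound 3 to compound 4 (0.13 log units; within the scatter) and, against the much smaller chloro, a 1.8-fold lower number from compound 1 to compound 4 (0.25 log units; within the scatter), so neither step stands out from the scatter. Among the compounds shown here, only the comparison with the 4-fluorophenyl group separates the new group from an earlier one, with a 2.6-fold lower number from compound 2 to compound 4 (0.41 log units; beyond the scatter) as the first step to pass beyond the scatter, and it is a modest one. Nothing measured here offers an explanation for these results.

From the compounds shown here alone, the sulfur link and the chloro on the ring enter together, so their separate contributions remain unknown. Also open, going by these compounds, is how an amine, a carboxylic acid or a longer alkyl chain at this position would read in this assay.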